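A few compounds are considered here, and "the series" means these few. Any claim that something is new, unique, unknown or untested is made for them only; others in the source may bear on it.

Three compounds share one core and differ only in the group on a saturated chain carbon bound to an aromatic carbon. Compound 1 `C[C@@H](O)Cc1cc(-c2ccnc3[nH]nc(C(F)(F)F)c23)cc(C2(C#N)CC2)c1` carries a 1-hydroxyethyl group there, and in an assay on isolated protein for inhibition of protein kinase C epsilon type (Homo sapiens), read by coupled enzyme assay (on this read-out higher numbers stand for weaker inhibition and lower numbers for stronger inhibition), compound 1 gives 34 nM. Compound 2 `N#CC1(c2cc(CC(O)C3CC3)cc(-c3ccnc4[nH]nc(C(F)(F)F)c34)c2)CC1` carries cyclopropyl(hydroxy)methyl instead, and in this assay compound 2 gives 30 nM; the step of a 1.1-fold lower number from compound 1 to compound 2 (0.05 log units; within the scatter). Compound 3 `COCC(O)Cc1cc(-c2ccnc3[nH]nc(C(F)(F)F)c23)cc(C2(C#N)CC2)c1` carries 1-hydroxy-2-methoxyethyl, and in this assay compound 3 gives 77 nM, the highest of the three numbers: the step of a 2.3-fold higher number from compound 1 to compound 3 (0.36 log units; beyond the scatter) and the step of a 2.6-fold higher number from compound 2 to compound 3 (0.41 log units; beyond the scatter).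

Compound 4 `CC(=O)OCCc1cc(-c2ccnc3[nH]nc(C(F)(F)F)c23)cc(C2(C#N)CC2)c1` has not yet been measured. It differs from compound 3 by acetoxymethyl in place of 1-hydroxy-2-methoxyethyl on a saturated chain carbon bound to an aromatic carbon. The two steps that end at compound 3 bear on this change, since both alter the same carbon, but neither removes the hydroxyl that all three measured compounds keep. Those steps were modest and both raised the number. Among the compounds with values here, with no measured precedent for losing the hydroxyl, compound 4 is expected to give about 100 nM in this assay, within 35 nM to 300 nM. The expected step of a 1.3-fold higher number from compound 3 to compound 4 (0.11 log units; within the scatter) is thus small, if any, and uncertain in direction.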

Compound 4, inhibition constant: 119 nM
Beside the measured number, compound 4's estimate is 1.2-fold (0.08 log units) below it; the range from low to high includes it.
By their numbers in this assay, from the lowest: compounds 2 and 1 (each within the scatter of the next); then compounds 3 and 4 (each within the scatter of the next).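

Within the data shown here, replacing 1-hydroxy-2-methoxyethyl, with 1 hydrogen-bond donor, by acetoxymethyl, with 0 hydrogen-bond donors and the same 5 heavy atoms, is the first change that removes the hydroxyl, and in this assay it gives a 1.5-fold higher number from compound 3 to compound 4 (0.19 log units; within the scatter) and so no separation between the two compounds. Measured against the two compounds at the low end of the series, the same group gives a 3.5-fold higher number from compound 1 to compound 4 (0.54 log units; beyond the scatter) and a 4.0-fold higher number from compound 2 to compound 4 (0.60 log units; beyond the scatter) in this assay as modest steps, so the hydroxyl on this chain is not essential for inhibition in these compounds, even though compound 4 sits above compound 1 and compound 2. Among these compounds, what the earlier compounds could not show is that a chain without the hydroxyl, and with a carbonyl in its place, still stays within the modest range of steps seen at this position.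

Compound 4 loses the hydroxyl and gains the acetoxy carbonyl in one change, so a simple 2-hydroxyethyl or 2-methoxyethyl chain, or a primary amine, would be needed to separate the two contributions. Nothing measured here accounts for the size of these steps.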